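A few compounds are considered here, and "the series" means these few. Any claim that something is new, unique, unknown or untested is made for them only; others in the source may bear on it.

Measured compounds:
- compound 1, `COc1ccc(CNCc2c(OC)cc(Oc3cccc(Nc4ccccc4)c3)cc2OC)cc1`: 1890 nM
- compound 2, `COc1cc(Oc2cccc(Nc3ccccc3)c2)cc(OC)c1CNCc1ccc(F)cc1`: 2750 nM
- compound 3, `COc1cc(Oc2cccc(Nc3ccccc3)c2)cc(OC)c1CNCCNC(C)=O`: 3960 nM

In a functional assay on HT-29 cells (Homo sapiens) for inhibition, read by MTT assay, with a stated time of 72 h (a lower number here means a stronger inhibitor, a higher number a weaker inhibitor), compound 2 gives 2750 nM, the second highest of the three numbers; compound 3 is nearest with 3960 nM and compound 1 furthest with 1890 nM, both gaps within the scatter, so no order among the three can be claimed.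

Compound 4, `COc1cc(Oc2cccc(Nc3ccccc3)c2)cc(OC)c1CCO`, is unmeasured. The change from compound 2 is hydroxymethyl in place of (4-fluorobenzyl)amino on a saturated chain carbon bound to an aromatic carbon.

For the measured compounds named here, no measured step removes the amine together with its benzyl group. The nearest comparisons exchange the benzyl part while keeping the amine: a 1.4-fold higher number from compound 2 to compound 3 (0.16 log units; within the scatter) and a 2.1-fold higher number from compound 1 to compound 3 (0.32 log units; beyond the scatter), both toward higher numbers, the second modest, the first within the scatter. Compound 4 loses more than either, so a higher number than compound 2 is expected in this assay, likely larger than those steps, with wide uncertainty: the expected step is a 2.9-fold higher number from compound 2 to compound 4 (0.46 log units; beyond the scatter).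

For compound 4 the estimate is 8000 nM, in the range 3000 nM to 25000 nM.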

Compound 4, half-maximal inhibitory concentration: 13900 nM
Beside the measured number, compound 4's estimate is 1.7-fold (0.24 log units) below it, within the range that was stated.
By their numbers in this assay, from the lowest: compounds 1, 2 and 3 (each within the scatter of the next, the first and the last beyond it); then compound 4.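

In this assay, for the compounds shown here, the earlier compounds varied only the group carried on the amine, whereas here the whole amine-bearing group gives way to hydroxymethyl on a saturated chain carbon bound to an aromatic carbon. The numbers rise whichever group leaves: (4-fluorobenzyl)amino (a 5.1-fold higher number from compound 2 to compound 4 (0.70 log units; beyond the scatter)), (2-acetamidoethyl)amino (a 3.5-fold higher number from compound 3 to compound 4 (0.55 log units; beyond the scatter)) or (4-methoxybenzyl)amino (a 7.4-fold higher number from compound 1 to compound 4 (0.87 log units; beyond the scatter)). Compound 3 carries no ring in this group and still has the lower number against compound 4, so a benzyl ring is not required for that gap.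

Nothing at hand gives a reason for these steps. Whether the nitrogen or the size of the group accounts for them stays open, and a simple primary amine or a carboxylic acid at this place would help separate the two.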